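The source may report more compounds than this note shows. Statements on the series, on what has been measured and on what is new or still open speak of the compounds shown alone.

Measured so far:
compound 1 `Oc1nc2nonc2nc1Nc1ccccc1F` — 12500 nM
compound 2 `Oc1nc2nonc2nc1Nc1ccc(OCc2ccccc2)cc1` — 2400 nM

In an assay on mitochondria from L6 cells (Rattus norvegicus) for activation, with a stated time of 90 min (a lower number here means that less compound is needed, a higher number that more compound is needed for the effect), compound 2 gives 2400 nM, the lower of the two numbers; compound 1 gives 12500 nM, a gap beyond the usual scatter. Compound 3 `CCCCc1ccc(Nc2nc3nonc3nc2O)cc1` differs from compound 2 in one place: butyl in place of benzyloxy on an aromatic carbon. Going by the values given here, no step between measured compounds covers such a change, so the size of the step is open. The expectation for compound 3 is a number somewhat higher than that of compound 2, a step of a 1.7-fold higher number from compound 2 to compound 3 (0.22 log units; within the scatter) that may stay within the scatter. Compound 3 is estimated at 4000 nM, with a range from 1500 nM to 11000 nM.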

Compound 3, half-maximal effective concentration: 2100 nM
Estimate against measurement, compound 3: 1.9-fold (0.28 log units) above; low and high end bracket the measured number.
By their numbers in this assay, from the lowest: compounds 3 and 2 (each within the scatter of the next); then compound 1.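

In this assay, going by these compounds alone, butyl in place of benzyloxy on an aromatic carbon, para to a large group, gives a 1.1-fold lower number from compound 2 to compound 3 (0.06 log units; within the scatter), the first reading of a single change at this position. Losing the six-membered aromatic ring and the oxygen of benzyloxy therefore leaves the number within the scatter in this one pair. No measured evidence bears on this result.

From the compounds shown here alone, whether an amine, a carboxylic acid or a longer chain at this position would keep the number within the scatter remains open. So does whether this replacement would read the same on another compound of the series.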